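Triazole aryl replaced by a short hydroxyalkyl chain

The compounds below may be only part of what the source reports. "The series", "measured", "known", "first", "only" and "open" are said of these compounds alone.

Compound 2 `O=C1O[C@H]([C@@H](O)Cn2cc(-c3cccc(O)c3)nn2)C(OCc2ccccc2)=C1OCc1ccccc1` stands second highest of the three numbers measured in a functional assay on MCF7 cells (Homo sapiens) for antiproliferative activity, read by MTT assay, with a stated time of 72 h (a lower number here means a stronger inhibitor, a higher number a weaker inhibitor), where compound 2 gives 51800 nM. Its nearest neighbour is compound 3 `COc1ccc(-c2cn(C[C@H](O)[C@H]3OC(=O)C(OCc4ccccc4)=C3OCc3ccccc3)nn2)cc1`, which in this assay gives 99700 nM; its furthest is compound 1 `O=C1O[C@H]([C@@H](O)Cn2cc(-c3ccc(Br)cc3)nn2)C(OCc2ccccc2)=C1OCc1ccccc1`, which in this assay gives 5620 nM. The shared core is kept throughout; the steps differ only in the group on the triazole.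

Compound 4 `O=C1O[C@H]([C@@H](O)Cn2cc(CCO)nn2)C(OCc2ccccc2)=C1OCc1ccccc1` is not yet measured. It differs from compound 2 as follows: 2-hydroxyethyl in place of 3-hydroxyphenyl on an aromatic carbon.

The measured steps bear on this only at a distance. The step of a 9.2-fold higher number from compound 1 to compound 2 (0.96 log units; beyond the scatter) and the step of an 18-fold higher number from compound 1 to compound 3 (1.25 log units; beyond the scatter) both trade one aryl group for another; the step of a 1.9-fold higher number from compound 2 to compound 3 (0.28 log units; within the scatter) is within the scatter. None removes the aryl ring, so compound 4 sits outside the measured ground. Compound 4 is expected to give 90000 nM, between 30000 nM and 270000 nM, in this assay. That estimate means a 1.7-fold higher number from compound 2 to compound 4 (0.24 log units; within the scatter), a weakening that may or may not clear the scatter.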

Compound 4, half-maximal inhibitory concentration: 63400 nM
Compound 4: middle estimate off by 1.4-fold (0.15 log units), on the high side, within the range that was stated.
By their numbers in this assay, from the lowest: compound 1; then compounds 2, 4 and 3 (each within the scatter of the next).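

In this assay the step of a 1.2-fold higher number from compound 2 to compound 4 (0.09 log units; within the scatter) and the step of a 1.6-fold lower number from compound 3 to compound 4 (0.20 log units; within the scatter) show that replacing the aryl ring with 2-hydroxyethyl, which has no ring, leaves the number within the scatter of both aryl compounds, so a six-membered aromatic ring on this triazole carbon does not by itself separate these compounds. Only the 4-bromophenyl group stands apart, with an 11-fold higher number from compound 1 to compound 4 (1.05 log units; beyond the scatter) as the step away from it, while the 3-hydroxyphenyl and 4-methoxyphenyl compounds 2 and 3 show that an aryl ring alone does not bring the lower number of compound 1. No supporting data bear on the reason for this result.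

Still open, on these data alone, is whether the lower number of compound 1 depends on the bromine or on its place, which plain phenyl and 3-bromophenyl groups could separate. Also open, as far as these compounds go, is whether an amine, a carboxylic acid or a longer chain in place of 2-hydroxyethyl would leave the number at this level.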